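Phenyl-to-methyl step on the aromatic ether side chain

A few compounds are considered here, and "the series" means these few. Any claim that something is new, unique, unknown or untested is made for them only; others in the source may bear on it.

Measured so far:
compound 1 `CCOc1ccc(Br)cc1C(C)NC(=O)N(C)S(=O)(=O)c1ccc(Cl)cc1` with 55700 nM
compound 2 `CC(NC(=O)N(C)S(=O)(=O)c1ccc(Cl)cc1)c1cc(Br)ccc1OCc1ccccc1` with 146000 nM
compound 3 `Cc1ccc(S(=O)(=O)NC(=O)NC(C)c2cc(Br)ccc2OCc2ccccc2)cc1` with 138000 nM

Of the compounds shown here, three have been measured in a functional assay on thoracic aorta (Rattus norvegicus, strain Wistar), with a stated time of 15 min; a lower number here means that less compound is needed, a higher number that more compound is needed for the effect. Compound 1 `CCOc1ccc(Br)cc1C(C)NC(=O)N(C)S(=O)(=O)c1ccc(Cl)cc1` gives 55700 nM, compound 2 `CC(NC(=O)N(C)S(=O)(=O)c1ccc(Cl)cc1)c1cc(Br)ccc1OCc1ccccc1` gives 146000 nM, and compound 3 `Cc1ccc(S(=O)(=O)NC(=O)NC(C)c2cc(Br)ccc2OCc2ccccc2)cc1` gives 138000 nM. Compound 2 and compound 1 differ in one place, (methyl in place of phenyl on a saturated chain carbon bound to an oxygen on an aromatic ring), and the step of a 2.6-fold lower number from compound 2 to compound 1 (0.42 log units; beyond the scatter) is modest but beyond the scatter. The values of compound 3 and compound 2 lie within the scatter of each other; the difference between the two cores is not broken down here.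

Compound 4 `CCOc1ccc(Br)cc1C(C)NC(=O)NS(=O)(=O)c1ccc(C)cc1` remains unmeasured. It differs from compound 3 by methyl in place of phenyl on a saturated chain carbon bound to an oxygen on an aromatic ring, the same change that took compound 2 to compound 1. Because compound 3 gives 138000 nM and the earlier step was a 2.6-fold lower number from compound 2 to compound 1 (0.42 log units; beyond the scatter), a step of similar size is expected in this assay, a 2.5-fold lower number from compound 3 to compound 4 (0.40 log units; beyond the scatter). Compound 4 is thus estimated at 55000 nM, with a likely range from 25000 nM to 120000 nM.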

Compound 4, half-maximal effective concentration: > 300000 nM
Compound 4 ended at the assay's limit (the forecaster's own chance of this, stated with the estimate: 15%); at least 5.4-fold (0.73 log units) between middle value and limit.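

In this assay, going from benzyloxy to ethoxy gives an at least 2.1-fold higher number from compound 3 to compound 4 (0.33 log units; beyond the scatter), so the change did not carry over from one core to the other, and the two steps run in opposite directions: the same change on two cores in this assay, a 2.6-fold lower number (0.42 log units; beyond the scatter) from compound 2 to compound 1 and an at least 2.1-fold higher number (0.33 log units; beyond the scatter) from compound 3 to compound 4, at least 5.6-fold (0.75 log units) apart, beyond the scatter of two such steps. Compound 4 gives > 300000 nM, which is a limit of the assay and not a number. These two pairs do not show how large the step on the core of compound 3 really is, nor why the two cores part ways.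

The compounds shown leave open which of the differences between the two cores goes with the opposite steps. They also leave open how a propyl chain or an amine in place of the phenyl would read on either core.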